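A few compounds are considered here, and "the series" means these few. Any claim that something is new, unique, unknown or untested is made for them only; others in the source may bear on it.

In an ADME assay on J774 cells (Mus musculus) for cytotoxicity (a higher number here means that more compound is needed for the effect, a lower number that less compound is needed), compound 1 `COC(=O)c1c[nH]c2cc(OCCOc3ccccc3)c(OC)cc2c1=O` gives > 20000 nM, which is a limit of the assay and not a number. Compound 2 `CCCCc1cc2c(=O)c(C(=O)OC)c[nH]c2cc1OCCOc1ccccc1` gives > 20000 nM, again a limit. Among the measured compounds shown here, compound 3 `COC(=O)c1c[nH]c2ccc(OCCc3ccccc3)cc2c1=O` gives 2200 nM, the only true number in the set. Compound 4 `CCOc1ccc2[nH]cc(C(=O)OC)c(=O)c2c1` has not yet been measured. It differs from compound 3 by hydrogen in place of phenyl on a saturated chain carbon, two bonds along the chain from an oxygen on an aromatic ring, so phenethyl becomes ethyl.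

For the measured compounds named here, the only measured step is a step that the two limits leave unreadable from compound 1 to compound 2. Going by the values given here, it changes a different place and gives no size to carry over, so no measured step bears directly on this change. What remains is the limit of > 20000 nM in this assay, at which 2 of the 3 values shown sit. Compound 3, at 2200 nM, still has room to rise, so a moderate upward shift is expected, though with wide uncertainty. The expected step is a 4.1-fold higher number from compound 3 to compound 4 (0.61 log units; beyond the scatter), and it would mean that more compound is needed for the effect. For compound 4 the estimate is 9000 nM, with an expected range from 2500 nM to 20000 nM.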

Compound 4, half-maximal effective concentration: > 20000 nM
Compound 4: no number, only a limit (the forecaster's own chance of this, stated with the estimate: 35%); middle value at least 2.2-fold (0.34 log units) away from the limit.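

In this assay, the phenyl on a saturated chain carbon, two bonds along the chain from an oxygen on an aromatic ring, now proves to matter, and the earlier step gave no such reading: replacing it with hydrogen, so that phenethyl becomes ethyl, gives an at least 9.0-fold higher number from compound 3 to compound 4 (0.95 log units; beyond the scatter). Compound 4 gives > 20000 nM, which is a limit of the assay and not a number. Compound 3 therefore remains the only compound here with a true number, and the other three all sit at the same limit: the limit of > 20000 nM in this assay, at which 3 of the 4 values shown sit.

The compounds shown leave open whether a propyl chain in place of the ethyl, or a cyclohexyl in place of the phenyl, would bring the number back towards that of compound 3. Also open, from the compounds shown here alone, is whether an amine on the end of the chain would do the same.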